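This account rests on a few compounds, and the source may have more. Where it says the series, first, only, none or still open, it means among the compounds named here.

Measured compounds in a functional assay on the whole organism (artery, strain albino) with Rattus norvegicus as the target, with a stated time of 120 min, at a dose of 10 mg/kg by the oral route; a higher number here means more inhibition at the dose given (going by the name of the read-out), a lower number less inhibition:
Compound 1, `CC1=C(C(=O)Nc2ccc(Br)cc2)C(c2ccc(Cl)cc2Cl)N=C(SCc2ccccc2)N1`, gives 10.3%.
Compound 2, `COc1ccc(C2N=C(SCc3ccccc3)NC(C)=C2C(=O)Nc2ccc(Br)cc2)cc1`, gives 8.2%.

For the measured compounds named here, compound 2 is one of only two measured compounds, and its value sits within the usual scatter of the value of compound 1; the single measured step, a number 2.1 percentage points lower from compound 1 to compound 2 (within the scatter), tells of no change beyond the scatter when 4-methoxyphenyl replaces 2,4-dichlorophenyl on a saturated ring carbon.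

Compound 3, `COc1ccc(C2N=C(SCc3cccc(Cl)c3)NC(C)=C2C(=O)Nc2ccc(Br)cc2)cc1`, differs from compound 2 by chloro in place of hydrogen on an aromatic carbon, that is, benzylsulfanyl becomes (3-chlorobenzyl)sulfanyl. Going by the values given here, no measured step touches this part of the shared core, so the only step known, from compound 1 to compound 2, bears on it merely as a sign that this assay has so far moved little between close analogues. A step beyond the scatter is therefore not expected in either direction, and the estimate for the change is a number 0.8 percentage points higher from compound 2 to compound 3 (within the scatter). Compound 3 is thus expected to give about 9%, within a range of 0% to 22%.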

Compound 3, a percentage reported as inhibition, in the whole organism at one dose (the size of the read-out at that dose, not a potency): 21.1%
Estimate against measurement, compound 3: 12.1 percentage points below; the measured number falls inside the stated range.
By their numbers in this assay, from the lowest: compounds 2 and 1 (each within the scatter of the next); then compound 3.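

Chloro in place of hydrogen on an aromatic carbon, which turns benzylsulfanyl into (3-chlorobenzyl)sulfanyl, gives a number 12.9 percentage points higher from compound 2 to compound 3 (beyond the scatter) in this assay and so shows that this part of the molecule can move the read-out. The earlier change, on a saturated ring carbon, gave a number 2.1 percentage points lower from compound 1 to compound 2 (within the scatter) and showed no such movement, so the benzyl ring is the only place shown so far where one change goes beyond the scatter. Nothing measured here says why the number moves at this position.

From the compounds shown here alone, whether fluoro, methoxy or an amine in the same place would give a similar step remains open. Going by these compounds, it is also open whether chloro would give this step on the benzyl ring with 2,4-dichlorophenyl on the saturated ring carbon.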